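This account rests on a few compounds, and the source may have more. Where it says the series, first, only, none or still open, it means among the compounds named here.

Of the compounds shown here, two with closely related structures have been measured so far in a physicochemical assay for solubility, read by nephelometry, at pH 7.4; a higher number here means a more soluble compound, a lower number a less soluble compound. There, compound 1 `COc1cccc(NC(=O)c2nnn(Cc3cc(C)on3)c2N)c1` gives 174000 nM, while compound 2 `COc1cccc(NC(=O)c2nnn(Cc3ccc(OC(F)(F)F)cc3)c2N)c1` gives 12000 nM. Compound 2 therefore holds the lower of the two numbers, and the gap between them lies beyond the usual scatter of repeated measurements.

Compound 3 `COc1cccc(NC(=O)c2nnn(Cc3ccc(C4CC4)cc3)c2N)c1` is built from compound 2 by a single change: cyclopropyl in place of trifluoromethoxy on an aromatic carbon, para to a large group (cyclopropyl in place of trifluoromethoxy on an aromatic carbon). Within the data shown here, no measured pair shows what this exchange does, so the expectation remains cautious: no change beyond the scatter in this assay, with at most a slight lean upward. The expected change is a 1.3-fold higher number from compound 2 to compound 3 (0.10 log units; within the scatter). For compound 3 the estimated solubility is 15000 nM, with an expected range from 6000 nM to 40000 nM.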

Compound 3, solubility: 79000 nM
For compound 3 the middle estimate is 5.3-fold (0.72 log units) below the measured one; the measured number lies above the stated range.
By their numbers in this assay, from the lowest: compound 2; then compound 3; then compound 1.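

In this assay, cyclopropyl in place of trifluoromethoxy on this aromatic carbon, para to a large group, gives a 6.6-fold higher number from compound 2 to compound 3 (0.82 log units; beyond the scatter), so the group at this one spot can shift the reading well beyond the scatter. The larger exchange gives a 2.2-fold lower number from compound 1 to compound 3 (0.34 log units; beyond the scatter), which shows that a compound with 4-cyclopropylphenyl in place of 5-methyl-1,2-oxazol-3-yl can still stay fairly close to compound 1. Nothing measured here explains why the number rises with cyclopropyl.

Going by these compounds, whether the difference follows the departing trifluoromethoxy or the entering cyclopropyl remains open, and a chlorine, an ethyl chain or an amine at the same carbon could help separate the two. On these data alone, it also remains open whether this exchange would have a similar effect on a different core.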